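Compound 3 to compound 4: bromo replaced by cyano

This account rests on a few compounds, and the source may have more. Where it says the series, first, only, none or still open, it means among the compounds named here.

Measured in a functional assay on RAW264.7 cells (Mus musculus) for inhibition, read by Griess assay, with stated times of 1 h and 24 h; on this read-out lower numbers stand for stronger inhibition and higher numbers for weaker inhibition:
- Compound 1 `CCC(C)Oc1ccc(C(O)C2OC(=O)c3c(OC)cc(OC)cc32)cc1` gives > 10000 nM, a limit of the assay.
- Compound 2 `C=CCCOc1ccc(C(O)C2OC(=O)c3c(OC)cc(OC)cc32)cc1` gives 1330 nM.
- Compound 3 `COc1cc(OC)c2c(c1)C(C(O)c1ccc(OCc3ccc(Br)cc3)cc1)OC2=O` gives 6530 nM.

Of the two true numbers, compound 3 holds the higher, and the other belongs to compound 2, with a 4.9-fold higher number from compound 2 to compound 3 (0.69 log units; beyond the scatter). Compound 1 stands only at its limit, so the comparison with it gives an at least 1.5-fold lower number from compound 1 to compound 3 (0.18 log units; that floor lies within the scatter).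

Compound 4 `COc1cc(OC)c2c(c1)C(C(O)c1ccc(OCc3ccc(C#N)cc3)cc1)OC2=O` departs from compound 3 in one place: cyano in place of bromo on an aromatic carbon. The change is cyano in place of bromo on an aromatic carbon, para to a large group.

For the measured compounds named here, no measured step makes this exchange. The two steps into compound 3 replace the whole group on the oxygen, so they offer only a loose guide to a change on its outer ring. No step beyond the scatter is therefore expected in this assay, and no direction is firmly favoured. The estimated step is a 1.2-fold lower number from compound 3 to compound 4 (0.07 log units; within the scatter). For compound 4 the expected value is 5500 nM, with an estimated range of 2000 nM to 10000 nM.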

Compound 4, half-maximal inhibitory concentration: 7360 nM
Beside the measured number, compound 4's estimate is 1.3-fold (0.13 log units) below it; the range from low to high includes it.
By their numbers in this assay, from the lowest: compound 2; then compounds 3 and 4 (each within the scatter of the next). At a limit, above all of these: compound 1.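

In this assay the exchange gives a 1.1-fold higher number from compound 3 to compound 4 (0.05 log units; within the scatter) when cyano replaces bromo on an aromatic carbon, para to a large group, so this change on the outer ring alone does not separate the two compounds. Compound 2 keeps its distance from the 4-cyanobenzyl compound as well, with a 5.5-fold higher number from compound 2 to compound 4 (0.74 log units; beyond the scatter) as the step beyond the scatter. Compound 1 stands only at a limit, so an at least 1.3-fold lower number from compound 1 to compound 4 (0.13 log units; that floor lies within the scatter) is a floor, and compound 4 cannot be ordered against it: the limit of > 10000 nM in this assay, at which 1 of the 4 values shown sits.

Going by these compounds, whether an amine or a carboxylic acid at that same aromatic carbon would move the number remains open. Also open, on these data alone, is whether a longer chain ending in a carbon-carbon double bond on the oxygen would give a lower or a higher number than compound 2, which gives 1330 nM in this assay.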